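Cyclopropyl in place of hexyl: a flat series so far

The source may report more compounds than this note shows. Statements on the series, on what has been measured and on what is new or still open speak of the compounds shown alone.

Of the compounds shown here, two have been measured in a functional assay, with a stated time of 30 min; a lower number here means a stronger inhibitor, a higher number a weaker inhibitor. Compound 1 `CC(C)=NNc1nc(-c2cccc([N+](=O)[O-])c2)cs1` gives 1160000 nM and compound 2 `CCCCCC/C(C)=N\Nc1nc(-c2cccc([N+](=O)[O-])c2)cs1` gives 1150000 nM, so the two stand level within the scatter.

The next structure is compound 3 `C/C(=N/Nc1nc(-c2cccc([N+](=O)[O-])c2)cs1)C1CC1`. The change is cyclopropyl in place of hexyl on a carbon with a double bond to nitrogen, in words cyclopropyl in place of hexyl on a carbon with a double bond to nitrogen.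

Within the data shown here, only one measured step bears on this. Pentyl in place of hydrogen on a saturated chain carbon bound to a carbon with a double bond to nitrogen gave a 1.0-fold lower number from compound 1 to compound 2 (0.00 log units; within the scatter), which lies within the scatter. That is a thin basis, and no ring at this place has been measured yet.

The expectation is therefore no step beyond the scatter, with an estimated 1.0-fold lower number from compound 2 to compound 3 (0.02 log units; within the scatter). For compound 3 the expected value is 1100000 nM, with an estimated range of 500000 nM to 2300000 nM.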

Compound 3, half-maximal inhibitory concentration: 1260000 nM
For compound 3 the middle estimate is 1.1-fold (0.06 log units) below the measured one; the measured number falls inside the stated range.
By their numbers in this assay, from the lowest: compounds 2, 1 and 3 (each within the scatter of the next).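

In this assay, the first ring at this place reads level with the open chains: a 1.1-fold higher number from compound 2 to compound 3 (0.04 log units; within the scatter), and a 1.1-fold higher number from compound 1 to compound 3 (0.04 log units; within the scatter). Compound 2 and compound 3 differ by a hexyl of 6 heavy atoms against a cyclopropyl of 3, so across the compounds shown, neither that difference in size nor the presence of a three-membered ring separates the numbers on a carbon with a double bond to nitrogen. No supporting measurement is available to explain why these compounds stand level.

As far as these compounds go, it remains open whether any group at this place can move the number beyond the scatter, for example an amine, a carboxylic acid or a phenyl ring. Also open, from the compounds shown here alone, is whether replacing the nitro group elsewhere on the shared core would break this flat reading.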